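Azetidinyl in Place of Propyl on the Ring Nitrogen

The compounds below may be only part of what the source reports. "The series", "measured", "known", "first", "only" and "open" are said of these compounds alone.

Within the data shown here, compound 2 `CCCn1c(=O)[nH]c2cc(NS(=O)(=O)c3cccc(Cl)c3Cl)c(OC)cc21` holds the higher of the two numbers measured so far: in a functional assay on CHO cells for antagonist activity at C-C chemokine receptor type 4 (Homo sapiens), read by radioligand binding and GTPgammaS binding (a higher number here means a weaker inhibitor, a lower number a stronger inhibitor), compound 2 gives 3980 nM. Among the measured compounds shown here, its nearest point is compound 1 `COc1cc2c(cc1NS(=O)(=O)c1cccc(Cl)c1Cl)[nH]c(=O)n2C(C)C`, which in this assay gives 1000 nM, and the one measured step, a 4.0-fold higher number from compound 1 to compound 2 (0.60 log units; beyond the scatter), is a modest one. Compound 3 `COc1cc2c(cc1NS(=O)(=O)c1cccc(Cl)c1Cl)[nH]c(=O)n2C1CNC1` differs from compound 2 at the same aromatic nitrogen: azetidin-3-yl in place of propyl on an aromatic nitrogen. For the measured compounds named here, no measured step covers a ring or a hydrogen-bond donor entering at this position; the only step that bears on it is a 4.0-fold higher number from compound 1 to compound 2 (0.60 log units; beyond the scatter), which shows that this position tolerates change without large shifts. Since a branched group enters again, compound 3 is expected to move back toward the number of compound 1. The expected step is a 3.2-fold lower number from compound 2 to compound 3 (0.50 log units; beyond the scatter). For compound 3 the estimate is 1250 nM, with a range from 250 nM to 6000 nM.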

Compound 3, half-maximal inhibitory concentration: 398 nM
Compound 3: middle estimate off by 3.1-fold (0.50 log units), on the high side; measured number inside the range.
By their numbers in this assay, from the lowest: compound 3; then compound 1; then compound 2.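

With azetidin-3-yl on the aromatic nitrogen, compound 3 holds the lowest number of the three in this assay, through a 10-fold lower number from compound 2 to compound 3 (1.00 log units; beyond the scatter) and a 2.5-fold lower number from compound 1 to compound 3 (0.40 log units; beyond the scatter). The earlier step between propyl and isopropyl showed only that this position tolerates a change of alkyl group, whereas this result shows that it also accepts a four-membered ring holding a nitrogen and a hydrogen-bond donor, with a number lower than that of either alkyl compound. Nothing measured here accounts for the gain. Cyclobutyl, the all-carbon four-membered ring, would help separate the contribution of the ring from that of its nitrogen. Also open, going by these compounds, are a methyl group on the azetidine nitrogen and a larger cyclic amine such as piperidin-4-yl at this position.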